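A few compounds are considered here, and "the series" means these few. Any claim that something is new, unique, unknown or untested is made for them only; others in the source may bear on it.

Measured so far in a functional assay on MIA PaCa-2 cells (Homo sapiens) for inhibition, read by MTT assay, with a stated time of 7 days; on this read-out higher numbers stand for weaker inhibition and lower numbers for stronger inhibition:
- compound 2 `CC(C)c1noc(N2CCN(C(=O)[C@@H]3CCCN(S(=O)(=O)c4ccc(S(=O)(=O)NC5CC5)cc4)C3)CC2)n1`: 1000 nM
- compound 1 `CCOC(=O)[C@@H]1C[C@H](O)CN(S(=O)(=O)c2ccc(S(=O)(=O)N(CC)CC)cc2)C1`: 1300 nM

In this assay compound 2 gives 1000 nM, and compound 1 gives 1300 nM; the two numbers lie within the usual scatter of each other, so neither stands apart and compound 2 has no separate standing on the numbers shown. Compound 3 `CC(C)c1noc(N2CCN(C(=O)[C@@H]3CCCN(S(=O)(=O)c4ccc(S(=O)(=O)NC(C)(C)C)cc4)C3)CC2)n1` differs from compound 2 in one place: tert-butyl in place of cyclopropyl on a sulfonamide nitrogen. Among the measured compounds shown here, no measured pair shows this change, so its direction is open. The step from compound 2 to compound 3 in this assay is expected to stay within the scatter, as no change at the digits printed from compound 2 to compound 3 (within the scatter). Compound 3 is therefore expected to give 1000 nM, between 400 nM and 2500 nM.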

Compound 3, half-maximal inhibitory concentration: 300 nM
Compound 3: the middle estimate sits 3.3-fold (0.52 log units) above what was measured; the measured number lies below the stated range.
By their numbers in this assay, from the lowest: compound 3; then compounds 2 and 1 (each within the scatter of the next).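

In this assay the group on the sulfonamide nitrogen can shift the number beyond the scatter: tert-butyl in place of cyclopropyl gives a 3.3-fold lower number from compound 2 to compound 3 (0.52 log units; beyond the scatter) as a modest step. Among the compounds shown here, the earlier compounds offered no comparison in one place, so this is the first reading at this position. Nothing at hand gives a reason for the step.

From the compounds shown here alone, whether a longer chain such as n-butyl, or a chain carrying an amine or a carboxylic acid, would extend this step remains open. A single pair also leaves open whether the step carries over to another core.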